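Chloro in place of fluoro: compound 3 to compound 4

A few compounds are considered here, and "the series" means these few. Any claim that something is new, unique, unknown or untested is made for them only; others in the source may bear on it.

Measured in a functional assay on V79 cells (Cricetulus griseus) for cytotoxicity, read by colony formation; on this read-out higher numbers stand for weaker inhibition and lower numbers for stronger inhibition:
- Compound 1 `CCNCC1CCN(c2c(F)cc3c(=O)c(C(=O)O)cn(C4CC4)c3c2Cl)C1`: 11 ug/mL; 11 ug/mL; < 11 ug/mL (3 entries)
- Compound 2 `CC1(CN)CCN(c2c(F)cc3c(=O)c(C(=O)O)cn(C4CC4)c3c2Cl)C1`: 8 ug/mL
- Compound 3 `CNCC1(C)CCN(c2c(F)cc3c(=O)c(C(=O)O)cn(C4CC4)c3c2F)C1`: 8 ug/mL

One of the entries for compound 1 is a limit of the assay and not a number: the several entries of compound 1 in this assay, 11 ug/mL; 11 ug/mL; < 11 ug/mL (3 entries).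

Compound 3 gives 8 ug/mL in this assay, and compound 2 gives 8 ug/mL, so the two stand level within the scatter. The next compound, compound 4 `CNCC1(C)CCN(c2c(F)cc3c(=O)c(C(=O)O)cn(C4CC4)c3c2Cl)C1`, has not yet been measured. It differs from compound 3 as follows: chloro in place of fluoro on an aromatic carbon. This is chloro in place of fluoro on an aromatic carbon.

Going by the values given here, no measured pair isolates this change. Compound 2, which already carries the chloro group, gives 8 ug/mL, so no large move is expected. The step expected is no change at the digits printed from compound 3 to compound 4 (within the scatter), with none beyond the scatter and no preferred direction. For compound 4 the estimated value is 8 ug/mL, with an expected range of 4 ug/mL to 15 ug/mL.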

Compound 4, half-maximal inhibitory concentration: 23 ug/mL
Compound 4: middle estimate off by 2.9-fold (0.46 log units), on the low side; measured number above the stated range.
By their numbers in this assay, from the lowest: compounds 2 and 3 (each within the scatter of the next); then compound 4.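

In this assay, chloro in place of fluoro on the aromatic carbon ortho to the 3-methyl-3-((methylamino)methyl)pyrrolidin-1-yl group gives a 2.9-fold higher number from compound 3 to compound 4 (0.46 log units; beyond the scatter) and so moves the read-out towards weaker inhibition, which shows that this position is not indifferent to the halogen when the amine nitrogen carries methyl. With chloro held in place, methyl in place of hydrogen on the amine nitrogen gives a 2.9-fold higher number from compound 2 to compound 4 (0.46 log units; beyond the scatter), so among these compounds the higher number goes with chloro and the nitrogen methyl together. Nothing measured here gives a reason for either step.

As far as these compounds go, what chloro in place of fluoro does with hydrogen on the amine nitrogen stays open. So does the read-out with a methoxy group or a bromo group on this aromatic carbon.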